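The source may report more compounds than this note shows. Statements on the series, on what has been measured and on what is new or still open speak of the compounds shown alone.

Working notes on the series in a functional assay on KBVIN cells (Homo sapiens) for antiproliferative activity, read by sulforhodamine B assay, with a stated time of 72 h; on this read-out higher numbers stand for weaker inhibition of growth and lower numbers for stronger inhibition of growth.

Among the measured compounds shown here, compound 1 `Cc1cc(=O)oc2cc(Sc3cccc(Cl)n3)ccc12` is the only member with a number so far: in this assay compound 1 gives 920 nM. Compound 2 `CCc1cc(=O)c2ccc(OC)c(CBr)c2o1` and compound 3 `CCOc1ccc2c(=O)cc(CC)oc2c1CBr` share a different core. Compound 2 in this assay reaches only a limit, > 33600 nM. Compound 3 in this assay likewise reaches only a limit, > 32100 nM. Compound 3 thus stands at the weak edge of what this assay resolves, and the step that the two limits leave unreadable from compound 2 to compound 3 cannot be sized because of the limit of > 32100 nM in this assay, at which 1 of the 3 values shown sits, and (the limit of > 33600 nM in this assay, at which 1 of the 3 values shown sits).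

Compound 4 `CCc1cc(=O)c2ccc(OC(C)C)c(CBr)c2o1` extends the same chain: methyl in place of hydrogen on a saturated chain carbon bound to an oxygen on an aromatic ring and a saturated chain carbon.

For the measured compounds named here, the only measured step on this core that bears on the change is a step that the two limits leave unreadable from compound 2 to compound 3, and it gives no size, since both of its ends are limits. No numeric anchor exists for the core of compound 3. The step that the limit leaves unreadable from compound 3 to compound 4 is therefore expected to be nothing beyond the scatter, and the likeliest outcome is another limit. Compound 4 is estimated at 40000 nM, with a range from 15000 nM to 100000 nM, and the expectation is that this assay again reports a limit rather than a number.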

Compound 4, concentration for 50% growth inhibition: > 30700 nM
Compound 4: only a limit was reported; the forecaster's own chance of this, stated with the estimate: 80%; the middle value is on the limit's open side.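

In this assay compound 4 reaches only a limit, > 30700 nM. Among the compounds shown here, with compound 2 and compound 3 also standing at limits, no step among compound 2, compound 3 and compound 4 can be read. The compounds shown leave open whether any change to the chain on the oxygen brings this core to a readable number.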